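From compound 2 to compound 3: a changed fluorophenyl side chain

The source may report more compounds than this note shows. Statements on the series, on what has been measured and on what is new or still open speak of the compounds shown alone.

In a functional assay on SK-MEL-28 cells (Homo sapiens) for inhibition, read by sulforhodamine B assay, with a stated time of 48 h (a lower number here means a stronger inhibitor, a higher number a weaker inhibitor), compound 1 `CN1CCCN(CCNc2nccc(-c3c(-c4cccc(O)c4)nc4sccn34)n2)S1(=O)=O` gives 240 nM and compound 2 `O=S(=O)(NCCCNc1nccc(-c2c(-c3cccc(O)c3)nc3sccn23)n1)c1cccc(F)c1` gives 2290 nM as the higher of the two numbers. Compound 3 `O=S(=O)(NCCNc1nccc(-c2c(-c3cccc(O)c3)nc3sccn23)n1)c1ccc(F)cc1` has not yet been measured. Its difference from compound 2 is ((4-fluorophenyl)sulfonyl)amino in place of (((3-fluorophenyl)sulfonyl)amino)methyl on a saturated chain carbon, two bonds along the chain from a nitrogen on an aromatic ring and amounts to ((4-fluorophenyl)sulfonyl)amino in place of (((3-fluorophenyl)sulfonyl)amino)methyl on a saturated chain carbon. Among the measured compounds shown here, the one measured step is a 9.5-fold higher number from compound 1 to compound 2 (0.98 log units; beyond the scatter) and it concerns a different exchange, so it guides the expectation only loosely. For the measured compounds named here, no measured step separates the parts of the present change. A small move towards a lower number is expected, well short of that measured step. The estimated step is a 2.3-fold lower number from compound 2 to compound 3 (0.36 log units; beyond the scatter) and may prove hard to tell from the scatter. For compound 3 the estimated value is 1000 nM with an expected range of 300 nM to 3000 nM once it is measured.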

Compound 3, half-maximal inhibitory concentration: 660 nM
Estimate against measurement, compound 3: 1.5-fold (0.18 log units) above, within the range that was stated.
By their numbers in this assay, from the lowest: compound 1; then compound 3; then compound 2.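

In this assay the exchange at this saturated chain carbon, ((4-fluorophenyl)sulfonyl)amino in place of (((3-fluorophenyl)sulfonyl)amino)methyl, gives a 3.5-fold lower number from compound 2 to compound 3 (0.54 log units; beyond the scatter) and so shows that the number here responds to changes within the fluorophenyl side chain, not only to the swap of the ring-bearing group. The fluorophenyl group does not recover the full strength of the non-aromatic six-membered ring group, since a 2.8-fold higher number from compound 1 to compound 3 (0.44 log units; beyond the scatter) remains beyond the scatter and leaves compound 1 with the lowest number of the three. Nothing available here accounts for either step.

As far as these compounds go, the shift of the fluorine and the loss of one carbon arrived together, so the share of each in the step remains open. Also open, from the compounds shown here alone, is how the number would respond to an amine or a carboxylic acid on the phenyl ring in place of the fluorine.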